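Cytotoxicity notes on a piperazinyl-triazine series

The compounds below may be only part of what the source reports. "The series", "measured", "known", "first", "only" and "open" are said of these compounds alone.

Measured compounds in an ADME assay on NIH3T3 cells (Mus musculus) for cytotoxicity, read by MTT assay, with a stated time of 24 h; a higher number here means a weaker inhibitor, a lower number a stronger inhibitor:
compound 1 `COc1cccc(N2CCN(CC(=O)N3CCN(c4nnc(-c5ccc(C)cc5)c(-c5ccc(C)cc5)n4)CC3)CC2)c1` gives > 866000 nM
compound 2 `Cc1ccc(-c2nnc(N3CCN(C(=O)CN4CCN(c5cccc(Cl)c5)CC4)CC3)nc2-c2ccc(C)cc2)cc1` gives 859000 nM
compound 3 `COc1ccc(-c2nnc(N3CCN(C(=O)CN4CCN(c5ccc(OC)cc5)CC4)CC3)nc2-c2ccc(OC)cc2)cc1` gives > 821000 nM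

The value of compound 1 is a limit of the assay, not a number. The value of compound 3 is likewise a limit, and not a number. For the measured compounds named here, compound 2 is the one compound of the three with a numerical reading, and that reading sits close to where the limits fall, as the limit of > 821000 nM in this assay, at which 1 of the 3 values shown sits, and the limit of > 866000 nM in this assay, at which 1 of the 3 values shown sits, show.

The step from compound 1 to compound 2 is chloro in place of methoxy on an aromatic carbon and gives a number no higher from compound 1 to compound 2 (the limit leaves the size open). The difference between the cores of compound 1 and compound 3 is not broken down here.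

Compound 4 `COc1ccc(-c2nnc(N3CCN(C(=O)CN4CCN(c5ccc(Cl)cc5)CC4)CC3)nc2-c2ccc(OC)cc2)cc1` is not yet measured. It differs from compound 3 by chloro in place of methoxy on an aromatic carbon. This is the same kind of change as that from compound 1 to compound 2, but the place differs: meta to a large group there, para to a large group here.

Since compound 3 gives only a limit and compound 2 reads near the same region, the step that the limit leaves unreadable from compound 3 to compound 4 is expected to be small, with a reading again likely to reach the limit. Compound 4 is estimated at 850000 nM, between 550000 nM and 1000000 nM.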

Compound 4, half-maximal inhibitory concentration: > 814000 nM
Compound 4 was reported as a limit; the forecaster's own chance of this, stated with the estimate: 65%; the middle value is on the limit's open side.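

Compound 3 gives > 821000 nM, a limit of the assay and not a number. Compound 4 gives > 814000 nM, likewise a limit and not a number. No step can be read between compound 3 and compound 4. The compounds shown leave open whether 4-methoxyphenyl to 4-chlorophenyl changes the reading on this core at all.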